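The source may hold more compounds than are shown below. What is called first, only, known or untested is meant among the compounds shown, and "the series" means these compounds.

Measured compounds:
- compound 1, `CCC(C)(C)Cc1c[nH]c(CCc2ccc(-n3ncnn3)cc2)n1`: 205 nM
- compound 2, `CCC(C)(C)Cc1c[nH]c(CCc2ccc(-c3cccc(C#N)n3)cc2)n1`: 140 nM
- compound 3, `CCC(C)(C)Cc1c[nH]c(CCc2ccc(-c3cccc(N)n3)cc2)n1`: 7.3 nM

These three numbers come from an in vitro assay on CHO cells for displacement of a labelled ligand from Bombesin receptor subtype-3 (Homo sapiens), read by scintillation counting, with a stated time of 2 h; on this read-out higher numbers stand for weaker inhibition and lower numbers for stronger inhibition. Compound 3 gives the lowest number of the three: the gap from compound 2 to it is a 19-fold lower number from compound 2 to compound 3 (1.28 log units; beyond the scatter), and from compound 1 to it a 28-fold lower number from compound 1 to compound 3 (1.45 log units; beyond the scatter), both beyond the scatter. The gap between compound 1 and compound 2, a 1.5-fold lower number from compound 1 to compound 2 (0.17 log units; within the scatter), is within the scatter.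

Compound 4, `CCC(C)(C)Cc1c[nH]c(CCc2ccc(-n3cncn3)cc2)n1`, has not been measured in this assay. It differs from compound 3 in one place: 1H-1,2,4-triazol-1-yl in place of 6-aminopyridin-2-yl on an aromatic carbon. For the measured compounds named here, the step that bears most on this change is the one from compound 1 to compound 3, since compound 1 also carries a five-membered ring with several nitrogens attached through a ring nitrogen in the same place; that step was a 28-fold lower number from compound 1 to compound 3 (1.45 log units; beyond the scatter). Compound 4 is therefore expected to lose most of what compound 3 shows, with an expected step of a 25-fold higher number from compound 3 to compound 4 (1.39 log units; beyond the scatter) towards a higher number. The estimate for compound 4 in this assay is 180 nM, with a range from 60 nM to 550 nM.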

Compound 4, half-maximal inhibitory concentration: 340 nM
The estimate for compound 4 lay 1.9-fold (0.28 log units) below the measured number; low and high end bracket the measured number.
By their numbers in this assay, from the lowest: compound 3; then compounds 2, 1 and 4 (each within the scatter of the next, the first and the last beyond it).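

With 1H-1,2,4-triazol-1-yl on this aromatic carbon, para to a large group, this assay gives a 47-fold higher number from compound 3 to compound 4 (1.67 log units; beyond the scatter) and so shows that a second five-membered aromatic ring attached through a ring nitrogen also falls far short of 6-aminopyridin-2-yl. Exchanging one such ring for the other gives a 1.7-fold higher number from compound 1 to compound 4 (0.22 log units; within the scatter) and so cannot be told apart from repeat scatter, which leaves 2H-tetrazol-2-yl and 1H-1,2,4-triazol-1-yl without a readable difference here. Against the nitrile-bearing pyridine the triazole gives a 2.4-fold higher number from compound 2 to compound 4 (0.39 log units; beyond the scatter) as a modest step, far smaller than the one from the aminopyridine. No measurement here accounts for the size of these steps. Still open, from the compounds shown here alone, is whether the amino group itself carries the gain, which an unsubstituted pyridin-2-yl or a methylamino or hydroxyl group in its place would test.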